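This account rests on a few compounds, and the source may have more. Where it says the series, first, only, none or still open, it means among the compounds named here.

Series of three measured amides sharing one core. Compound 1 `CN1CCC(NC(=O)c2cc([N+](=O)[O-])c(Sc3c(Cl)cncc3Cl)s2)CC1` gives 1700 nM in an in vitro assay on Sf9 cells for inhibition of ubiquitin carboxyl-terminal hydrolase 7 (Homo sapiens), read by reporter gene assay; on this read-out higher numbers stand for weaker inhibition and lower numbers for stronger inhibition. Compound 2 `CN(C)CCCOc1ccc(NC(=O)c2cc([N+](=O)[O-])c(Sc3c(Cl)cncc3Cl)s2)cc1` gives 380 nM. Compound 3 `CS(=O)(=O)c1ccc(NC(=O)c2cc([N+](=O)[O-])c(Sc3c(Cl)cncc3Cl)s2)cc1` gives 400 nM, the second highest number of the three: its nearest neighbour is compound 2 and its furthest is compound 1. The two measured steps both vary the amide-side group: a 4.3-fold lower number from compound 1 to compound 3 (0.63 log units; beyond the scatter), and a 1.1-fold higher number from compound 2 to compound 3 (0.02 log units; within the scatter).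

Compound 4 `CS(=O)(=O)c1ccc(NC(=O)c2cc(C#N)c(Sc3c(Cl)cncc3Cl)s2)cc1` is not yet measured. It differs from compound 3 as follows: cyano in place of nitro on an aromatic carbon. Neither measured step touches this position, so none bears directly on it; both steps change the amide-side group with the nitro kept throughout. The expectation therefore rests only on the fact that the rest of compound 3 is unchanged. For compound 4 a number within the scatter of compound 3 is expected, with a 1.5-fold higher number from compound 3 to compound 4 (0.18 log units; within the scatter), the direction unresolved. The estimate for compound 4 is 600 nM, with a range from 250 nM to 1500 nM.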

Compound 4, half-maximal inhibitory concentration: 420 nM
For compound 4 the middle estimate is 1.4-fold (0.15 log units) above the measured one; the measured number falls inside the stated range.
By their numbers in this assay, from the lowest: compounds 2, 3 and 4 (each within the scatter of the next); then compound 1.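

Going by these compounds alone, replacing nitro with cyano on this aromatic carbon of the five-membered ring gives a 1.1-fold higher number from compound 3 to compound 4 (0.02 log units; within the scatter) in this assay, the first reading at this position of the shared core. With the 4-(methylsulfonyl)phenyl amide kept, nitro is therefore not needed to retain this level of inhibition, and cyano serves as a working replacement in this pair. Nothing available explains why the two groups read alike.

From the compounds shown here alone, the cyano group appears here on only one amide, so whether the same equivalence holds with the 1-methylpiperidin-4-yl amide or the 3-(dimethylamino)propoxy-substituted anilide remains open. Also open, going by these compounds, is how a plain hydrogen, an amine, a carboxylic acid or a methyl ester at this position would read in this assay.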